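Fluoro Added to a Second Core in A549 Cells

A few compounds are considered here, and "the series" means these few. Any claim that something is new, unique, unknown or untested is made for them only; others in the source may bear on it.

Compound 1 `O=C1Nc2ccccc2C1(c1c[nH]c2ccccc12)c1c[nH]c2ccccc12` gives 8600 nM in a functional assay on A549 cells (Homo sapiens) for cytotoxicity, read by MTT assay, with a stated time of 48 h; a higher number here means a weaker inhibitor, a lower number a stronger inhibitor.
Compound 2 `COc1ccc2[nH]cc(C3(c4c[nH]c5ccc(OC)cc45)C(=O)Nc4ccccc43)c2c1` gives 11200 nM in this assay.
Compound 3 `O=C1Nc2ccc(F)cc2C1(c1c[nH]c2ccccc12)c1c[nH]c2ccccc12` gives 12700 nM in this assay.

All three compounds inhibit the cells only weakly, and their three numbers lie within the scatter of one another. Compound 3 differs from compound 1 by a single change, (fluoro in place of hydrogen on an aromatic carbon), and this step came out as a 1.5-fold higher number from compound 1 to compound 3 (0.17 log units; within the scatter). The difference between the core of compound 1 and the core of compound 2 is not broken down here; what can be said is that compound 2 and compound 1 give numbers that sit close together.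

Compound 4 `COc1ccc2[nH]cc(C3(c4c[nH]c5ccc(OC)cc45)C(=O)Nc4ccc(F)cc43)c2c1` has not yet been measured in this assay. Among the compounds with values here, it differs from compound 2 by fluoro in place of hydrogen on an aromatic carbon, which is the same change, made at the same kind of place, as the one from compound 1 to compound 3. The step from compound 2 to compound 4 is expected to be about a 1.3-fold higher number from compound 2 to compound 4 (0.13 log units; within the scatter) because a 1.5-fold higher number from compound 1 to compound 3 (0.17 log units; within the scatter) stayed within the scatter. Compound 4 is therefore estimated at 15000 nM, most likely somewhere between 7000 nM and 35000 nM. The measurement will show whether the second core behaves like the first.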

Compound 4, half-maximal inhibitory concentration: 10600 nM
For compound 4 the middle estimate is 1.4-fold (0.15 log units) above the measured one, within the range that was stated.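

In this assay, fluoro in place of hydrogen on the second core gave a 1.1-fold lower number from compound 2 to compound 4 (0.02 log units; within the scatter), so this step, like the one on the first core, is too small to separate from ordinary repeat variation. Set side by side, the two steps do not differ by more than their scatter: the same change on two cores in this assay, a 1.5-fold higher number (0.17 log units; within the scatter) from compound 1 to compound 3 and a 1.1-fold lower number (0.02 log units; within the scatter) from compound 2 to compound 4, 1.6-fold (0.19 log units) apart, within the scatter of two such steps

This shows that, for these two cores, the change carried across without a difference that this assay can detect, but it does not show that the cores respond in the same way, since neither step is large enough to reveal a real effect that could be compared, and two cores cannot speak for others.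

At this place on the ring, the compounds shown carry only hydrogen or fluoro, so it remains open whether a larger or differently built group, such as trifluoromethyl, a nitrile or an amine, would shift the number beyond the scatter. From the compounds shown here alone, it also remains open whether such a shift would then carry from one core to the other.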